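The source may hold more compounds than are shown below. What is called first, only, known or untested is meant among the compounds shown, and "the series" means these compounds.

Compound 1 `C=CCn1c(=O)/c(=C\c2cccc(Cl)c2)[nH]c(=O)/c1=C\c1ccccc1OC` and compound 2 `C=CCn1c(=O)/c(=C\c2ccc(Cl)c(Cl)c2)[nH]c(=O)/c1=C\c1ccccc1OC` share a core that carries an allyl group and a 2-methoxyphenyl-bearing arm, and they differ only in the halogenated aryl group on the other arm. In a functional assay on HeLa cells (Homo sapiens) for cytotoxicity, read by CCK-8 assay, with a stated time of 72 h (a higher number here means a weaker inhibitor, a lower number a stronger inhibitor), compound 1 gives 5500 nM, whereas compound 2 is recorded as "not active" (no number reported), so no single number places compound 2 on the scale; on the numbers shown it stands as the member without a measured potency, while compound 1 holds the only reported value. Compound 3 `C=CCn1c(=O)/c(=C\c2cc(Br)ccc2F)[nH]c(=O)/c1=C\c1ccccc1OC` is not yet measured. It differs from compound 2 in one place: 5-bromo-2-fluorophenyl in place of 3,4-dichlorophenyl on a double-bonded chain carbon bound to an aromatic carbon. Going by the values given here, no step between measured compounds covers this kind of change, and the two halogenated analogues already seen give only one number and one inactive result, so the expected size of the step in this assay cannot be drawn from a measured pair; a weak or absent inhibition seems the more likely outcome, with an appreciable chance that only a limit is reported. Compound 3 is expected to give about 9000 nM, within a range from 2500 nM to 40000 nM.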

Compound 3, half-maximal inhibitory concentration: 34600 nM
The estimate for compound 3 lay 3.8-fold (0.58 log units) below the measured number, and the stated range covers the measured number.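

In this assay the halogenated aryl group proves sensitive to substitution: 5-bromo-2-fluorophenyl in place of 3-chlorophenyl on a double-bonded chain carbon bound to an aromatic carbon gives a 6.3-fold higher number from compound 1 to compound 3 (0.80 log units; beyond the scatter) and so weakens the compound beyond the usual scatter. Compound 3 still has a measured number while compound 2, with 3,4-dichlorophenyl, is recorded as not active, so the step between these two cannot be read. Nothing measured here speaks to the reason for the loss.

The bromine and the fluorine enter together, so the compounds shown do not separate what each contributes to the step. As far as these compounds go, it also remains open how this assay would respond to a group without halogen on this aryl ring, such as an amine or a carboxylic acid.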